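The source may hold more compounds than are shown below. What is called first, only, known or untested is meant among the compounds shown, and "the series" means these compounds.

The compounds share one core, a diamine-bearing ring system with a phenyl group and a benzylamine arm, and they differ in what that arm carries. Compound 2 `Nc1cc(N)c2nc(-c3ccccc3)c(NCc3ccc(Cl)c(Cl)c3)nc2c1` carries a 3,4-dichlorobenzyl arm. In a functional assay on NCI-H522 cells (Homo sapiens) for inhibition, read by sulforhodamine B assay, with a stated time of 48 h (a higher number here means a weaker inhibitor of growth, a lower number a stronger inhibitor of growth), compound 2 gives 2040 nM. Compound 1 `CCOC(=O)[C@H](CCC(=O)O)NC(=O)c1ccc(CNc2nc3cc(N)cc(N)c3nc2-c2ccccc2)cc1`, whose arm bears an ester-carrying side chain, gives 26900 nM in this assay, so compound 2 holds the lowest of the two numbers, and the gap to compound 1 lies beyond the scatter. Compound 3 `COc1cc(CNc2nc3cc(N)cc(N)c3nc2-c2ccccc2)cc(OC)c1OC` gives only a limit in this assay, < 50200 nM, of the kind noted as the limit of < 50200 nM in this assay, at which 1 of the 3 values shown sits.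

Compound 4 `Nc1cc(N)c2nc(-c3ccccc3)c(NCc3ccc(F)cc3)nc2c1` has not yet been measured. It differs from compound 2 in one place: 4-fluorophenyl in place of 3,4-dichlorophenyl on a saturated chain carbon bound to a nitrogen on an aromatic ring. For the measured compounds named here, no measured pair differs in a single place, so the size of such a step cannot be read from the data. Compound 4 is expected to give about 5500 nM in this assay, within a range of 1500 nM to 22000 nM. The expected step from compound 2 to compound 4 is a 2.7-fold higher number from compound 2 to compound 4 (0.43 log units; beyond the scatter), toward a higher number, and it may or may not pass beyond the scatter.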

Compound 4, concentration for 50% growth inhibition: < 100000 nM
Compound 4: no number, only a limit; the forecaster's own chance of this, stated with the estimate: 15%; the middle value lies beyond the limit too.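

In this assay compound 4 gives < 100000 nM, which is a limit and not a number. The step between compound 2 and compound 4 cannot be read from it. The compounds shown leave open how the 4-fluorobenzyl arm compares with the 3,4-dichlorobenzyl arm in growth inhibition.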